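A few compounds are considered here, and "the series" means these few. Any claim that something is new, unique, unknown or untested is made for them only; others in the source may bear on it.

Among the compounds with values here, the three compounds measured so far share one core and differ only in the chain carried on the carbonyl carbon of the amide. Compound 1 `CC(=O)Nc1c(C(O)(C(F)(F)F)C(F)(F)F)ccc2ccccc12` gives in an assay on LtK cells with ATP-sensitive inward rectifier potassium channel 11 (Homo sapiens) as the target (on this read-out higher numbers stand for an effect only at larger amounts of compound and lower numbers for an effect already at smaller amounts), a value of 18 nM. Compound 2 `CCCC(=O)Nc1c(C(O)(C(F)(F)F)C(F)(F)F)ccc2ccccc12` gives 131 nM in this assay. Compound 3 `CCCC(C)C(=O)Nc1c(C(O)(C(F)(F)F)C(F)(F)F)ccc2ccccc12` reaches only a limit of this assay, > 10000 nM. Among the numbers shown, compound 2 stands highest of the two, with compound 1 nearest and separated by the step of a 7.3-fold higher number from compound 1 to compound 2 (0.86 log units; beyond the scatter).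

Compound 4 `O=C(Nc1c(C(O)(C(F)(F)F)C(F)(F)F)ccc2ccccc12)C1CC1` arises from compound 2 by the change (cyclopropyl in place of propyl on a carbonyl carbon). Within the data shown here, two measured steps bear on this. Lengthening the chain from compound 1 gave a 7.3-fold higher number from compound 1 to compound 2 (0.86 log units; beyond the scatter), a modest step; the far bulkier, branched chain gave an at least 76-fold higher number from compound 2 to compound 3 (1.88 log units; beyond the scatter), a large step. Cyclopropyl keeps the same count of carbons as propyl but closes them into a ring, so it is more compact than propyl and not larger. On that basis the step to compound 4 is expected to stay small, most likely within the scatter or slightly downward.

Compound 4 is therefore expected to give 80 nM in this assay, with a range from 25 nM to 400 nM. This estimate corresponds to an expected step of a 1.6-fold lower number from compound 2 to compound 4 (0.21 log units; within the scatter).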

Compound 4, half-maximal effective concentration: 751 nM
For compound 4 the middle estimate is 9.4-fold (0.97 log units) below the measured one; measured number outside the range, above it.
By their numbers in this assay, from the lowest: compound 1; then compound 2; then compound 4. At a limit, above all of these: compound 3.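

Carbon count alone does not set the value on this carbonyl carbon: propyl and cyclopropyl carry the same count of carbons, yet closing them into a ring gives a 5.7-fold higher number from compound 2 to compound 4 (0.76 log units; beyond the scatter), so in this assay the ring brings no gain over the open chain. The ring also stays well away from the small methyl group, with a 42-fold higher number from compound 1 to compound 4 (1.62 log units; beyond the scatter), which means that neither of the two larger groups with a measured number comes close to methyl. Against the branched 1-methylbutyl chain, the comparison can only be read as a bound, with an at least 13-fold lower number from compound 3 to compound 4 (1.12 log units; beyond the scatter), since that chain's value is a limit and not a number: the limit of > 10000 nM in this assay, at which 1 of the 4 values shown sits.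

The compounds shown leave open whether a larger ring such as cyclopentyl, or a short branched chain such as isopropyl, would read nearer to methyl or nearer to propyl and cyclopropyl. They also do not tell how an amine or a carboxylic acid at the end of the chain would read in this assay.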